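Taking one methoxy off compound 3

A few compounds are considered here, and "the series" means these few. Any claim that something is new, unique, unknown or untested is made for them only; others in the source may bear on it.

In a functional assay on K562 cells (Homo sapiens) for antiproliferative activity, read by MTT assay, with a stated time of 5 days (a higher number here means a weaker inhibitor, a lower number a stronger inhibitor), compound 1 `COc1ccc(C(=Cc2ccc(OC)c([N+](=O)[O-])c2)C(=O)c2cc(OC)c(OC)c(OC)c2)cc1` gives 2660000 nM, compound 2 `COc1ccc(C=C(C(=O)c2cc(OC)c(OC)c(OC)c2)c2ccccc2O)cc1` gives 240000 nM and compound 3 `COc1ccc(C=C(C(=O)c2cc(OC)c(OC)c(OC)c2)c2ccc(C)cc2)cc1` gives 760000 nM, the second highest of the three numbers. Compound 4 `COc1cc(C(=O)C(=Cc2ccccc2)c2ccc(C)cc2)cc(OC)c1OC` has hydrogen in place of methoxy on an aromatic carbon, para to a large group: hydrogen in place of methoxy on an aromatic carbon. Among the compounds with values here, the only measured step, a 3.2-fold higher number from compound 2 to compound 3 (0.50 log units; beyond the scatter), lies at another place, so it shows the scale of change but not its direction here. Within the data shown here, no measured pair tests this methoxy, so no step beyond the scatter is expected in this assay. The estimated step is a 1.1-fold higher number from compound 3 to compound 4 (0.05 log units; within the scatter). For compound 4 the expected value is 850000 nM, with an estimated range of 280000 nM to 2500000 nM.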

Compound 4, half-maximal inhibitory concentration: 2970000 nM
The estimate for compound 4 lay 3.5-fold (0.54 log units) below the measured number, and the stated range ends below it.
By their numbers in this assay, from the lowest: compound 2; then compound 3; then compounds 1 and 4 (each within the scatter of the next).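

In this assay, going from 4-methoxyphenyl to phenyl gives a 3.9-fold higher number from compound 3 to compound 4 (0.59 log units; beyond the scatter) and so leaves a weaker inhibitor. Within the data shown here, this is the first measured test of this methoxy, and it shows that the position responds to the change and that losing the methoxy moves the number upward. Nothing available bears on why the number rises. From the compounds shown here alone, whether an amine or a hydroxy group in place of this methoxy would hold the number of compound 3 stays open. So does whether removing the methoxy has the same effect when the 2-hydroxyphenyl group of compound 2 is present.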